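Guanidine in place of an amine hydrogen on a charged purinium thioacetamide

The compounds below may be only part of what the source reports. "The series", "measured", "known", "first", "only" and "open" are said of these compounds alone.

The measured compounds:
Compound 1 `CCN(CC)CC[n+]1c(SCC(=O)NCCN)[nH]c2c(C)nc(N(CC)CC)nc21`: in an ADME assay on CEM174 cells (Homo sapiens) for cytotoxicity (a lower number here means that less compound is tolerated, a higher number that more compound is tolerated), compound 1 gives 52.2 uM.
Compound 2 `CCN(CC)c1nc(C)c2[nH]c(SCC(=O)NCCN)[n+](CCCN(C)C)c2n1`: in this assay compound 2 gives > 100 uM, which is a limit of the assay and not a number.

Compound 2 therefore stands at the upper end of what this assay can report, as the limit of > 100 uM in this assay, at which 1 of the 2 values shown sits, states. Its position relative to compound 1 is set only by an at least 1.9-fold higher number from compound 1 to compound 2 (0.28 log units; that floor lies within the scatter).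

Compound 3 `CCN(CC)c1nc(C)c2[nH]c(SCC(=O)NCCNC(=N)N)[n+](CCCN(C)C)c2n1` differs from compound 2 by a group of 3 heavy atoms (1 carbon, 2 nitrogen; no ring) in place of a hydrogen atom, on an amine nitrogen. Within the data shown here, the only measured step, an at least 1.9-fold higher number from compound 1 to compound 2 (0.28 log units; that floor lies within the scatter), concerns the chain carbon two bonds from the aromatic nitrogen and not the amine nitrogen, so no measured step bears directly on the change from compound 2 to compound 3. The guanidine group enters at the end of the chain, away from the part of the core that the measured step touches, and nothing in the numbers points to a direction.

The estimate for compound 3 is therefore that it stays at the limit, with a number no higher from compound 2 to compound 3 (the limit leaves the size open) expected to lie within the scatter. Compound 3 is expected to give 100 uM, between 40 uM and 300 uM.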

Compound 3, half-maximal toxic concentration: > 100 uM
Compound 3: no number, only a limit; the forecaster's own chance of this, stated with the estimate: 70%; the middle value lies on the limit itself.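

In this assay compound 3 gives > 100 uM, which is a limit of the assay and not a number. Among these compounds, compound 2 sits at the same limit, so no step from compound 2 to compound 3 can be read. The compounds shown leave open whether the group entering on the amine nitrogen changes the tolerated concentration at all, and in which direction.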